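Sulfur in place of oxygen at the piperidine nitrogen cap

The compounds below may be only part of what the source reports. "The series", "measured", "known", "first", "only" and "open" are said of these compounds alone.

Measured so far in a functional assay on CHO-K1 cells with Glucose-dependent insulinotropic receptor (Homo sapiens) as the target, read by a luciferase reporter, with a stated time of 5 h; a lower number here means a smaller maximal response, a higher number a larger maximal response:
compound 1 `CC(C)OC(=O)N1CCC(Oc2ncnc3c2CCN3c2ccc(S(C)(=O)=O)cc2F)CC1` gives 91%;
compound 2 `CCSC(=O)N1CCC(Oc2ncnc3c2CCN3c2ccc(S(C)(=O)=O)cc2F)CC1` gives 128%.

Among the compounds with values here, compound 2 stands highest of the two values shown; its nearest neighbour is compound 1, and the only step measured, a number 37 percentage points higher from compound 1 to compound 2 (beyond the scatter), is large and beyond the scatter. Compound 3 `CS(=O)(=O)c1ccc(N2CCc3c(OC4CCN(C(=S)Sc5ccccc5)CC4)ncnc32)c(F)c1` has not yet been measured. It differs from compound 2 by a group of 9 heavy atoms (7 carbon, 2 sulfur; one six-membered aromatic ring of carbon only) in place of a group of 5 heavy atoms (3 carbon, 1 oxygen, 1 sulfur; no ring), on an amine nitrogen in a ring. The step from compound 1 to compound 2 bears on this change, since there too a sulfur-bearing group replaced an oxygen-bearing one on the same ring nitrogen, and the maximal response rose markedly. Within the data shown here, no step covers the entry of a ring, so the expectation is uncertain; a modest step downward or one within the scatter is expected, a number 18 percentage points lower from compound 2 to compound 3 (beyond the scatter). Compound 3 is estimated to give 110%, between 70% and 145%.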

Compound 3, largest response reached (reported as percent of maximum), in percent of the reference or control that the assay uses: 103%
Estimate against measurement, compound 3: 7 percentage points above, and the stated range covers the measured number.
By their numbers in this assay, from the lowest: compound 1; then compound 3; then compound 2.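

In this assay, placing a group of 9 heavy atoms with a six-membered aromatic ring of carbon only on the amine nitrogen in the ring gives a number 25 percentage points lower from compound 2 to compound 3 (beyond the scatter), so this larger group does not keep the full response seen with (ethylsulfanyl)carbonyl. The same group still gives a number 12 percentage points higher from compound 1 to compound 3 (beyond the scatter), so in this set both sulfur-bearing groups stand above the oxygen-bearing isopropoxy group, and a ring at this position is compatible with a high maximal response. No supporting data bear on why these groups differ in this way.

The compounds shown leave open whether the aromatic ring or the added sulfur accounts for the drop from compound 2, since both enter together. A phenoxycarbonyl group, or a cyclohexyl ring on the same sulfur-bearing link, would help separate the two.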